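Hydrazone series: aryl variation on the carbonyl carbon

This account rests on a few compounds, and the source may have more. Where it says the series, first, only, none or still open, it means among the compounds named here.

Compound 1 `O=C(N/N=C/C1=C(Cl)c2ccccc2CCC1)c1cccc(Cl)c1`: 19200 nM
Compound 2 `Nc1ccccc1C(=O)N/N=C/C1=C(Cl)c2ccccc2CCC1`: > 100000 nM

In a functional assay on HeLa cells (Homo sapiens) for inhibition, read by sulforhodamine B assay, with a stated time of 48 h (on this read-out lower numbers stand for stronger inhibition of growth and higher numbers for weaker inhibition of growth), compound 1 gives 19200 nM. For compound 2 this assay reports only a limit, > 100000 nM. Of the two values shown, one sits at the limit of > 100000 nM in this assay, at which 1 of the 2 values shown sits, so compound 2 stands only at that limit. For the measured compounds named here, the single measured step, an at least 5.2-fold higher number from compound 1 to compound 2 (0.71 log units; beyond the scatter), is the only one that bears on the next change. Compound 3 `O=C(N/N=C/C1=C(Cl)c2ccccc2CCC1)c1cccnc1` is not yet measured; it differs from compound 2 by pyridin-3-yl in place of 2-aminophenyl on a carbonyl carbon. The hydrogen-bond donor of the 2-aminophenyl group leaves with it and an aromatic nitrogen enters; whether this recovers the level of compound 1 is open. Compound 3 is expected to fall between the two measured points, at an estimated 45000 nM with a range of 12000 nM to 150000 nM. The expected step is an at least 2.2-fold lower number from compound 2 to compound 3 (0.34 log units; beyond the scatter), with a real chance that this assay again reports only a limit.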

Compound 3, concentration for 50% growth inhibition: 7500 nM
For compound 3 the middle estimate is 6.0-fold (0.78 log units) above the measured one; the measured number lies below the stated range.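

In this assay, the group on the carbonyl carbon can lower the number as well as raise it: pyridin-3-yl gives a 2.6-fold lower number from compound 1 to compound 3 (0.41 log units; beyond the scatter), which makes compound 3 the most potent of the three compounds shown. The same group gives an at least 13-fold lower number from compound 2 to compound 3 (1.12 log units; beyond the scatter), so an aromatic ring with a hetero atom is accepted at this place and the series is not confined to carbon-only aryl groups. The size of that step is only a lower bound, as compound 2 stands at a limit of the assay: the limit of > 100000 nM in this assay, at which 1 of the 3 values shown sits.

As far as these compounds go, whether the level of compound 3 depends on the ring nitrogen or on the absence of the chlorine of compound 1 remains open, and an unsubstituted phenyl would separate the two. From the compounds shown here alone, whether the nitrogen's place in the ring matters is also open, a question pyridin-4-yl would address.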